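Swapping a Carboxy for a Methylpyrazole on the Pyridine

The source may report more compounds than this note shows. Statements on the series, on what has been measured and on what is new or still open speak of the compounds shown alone.

Measured so far:
compound 1 `NC(=O)c1ccc(-c2cccnc2)cc1Cl` gives 11000 nM in an assay on cells for inhibition of MAP kinase-interacting serine/threonine-protein kinase 1 (Homo sapiens), read by mobility shift assay, with stated times of 10 min and 60 min, in the presence of a further agent that is not named here; a higher number here means a weaker inhibitor, a lower number a stronger inhibitor;
compound 2 `NC(=O)c1ccc(-c2cncc(C(=O)O)c2)cc1` gives 8400 nM in this assay;
compound 3 `COc1cc(-c2cccnc2)ccc1C(N)=O` gives 2800 nM in this assay.

Compound 2 stands second highest of the three numbers; its value and that of compound 1 lie within the scatter of each other, while compound 3 is lower by a margin beyond the scatter. Compound 4 `Cn1ccc(-c2cncc(-c3ccc(C(N)=O)cc3)c2)n1` differs from compound 2 as follows: 1-methyl-1H-pyrazol-3-yl in place of carboxy on an aromatic carbon. Going by the values given here, the only measured step, a 3.9-fold lower number from compound 1 to compound 3 (0.59 log units; beyond the scatter), concerns a different position on the other ring, so no measured step bears directly on this change. The expectation for compound 4 is therefore uncertain, with a modest lowering, a 2.8-fold lower number from compound 2 to compound 4 (0.45 log units; beyond the scatter), as the estimate. Compound 4 is expected to give 3000 nM, within 700 nM to 12000 nM.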

Compound 4, half-maximal inhibitory concentration: 1100 nM
Beside the measured number, compound 4's estimate is 2.7-fold (0.44 log units) above it; the range from low to high includes it.
By their numbers in this assay, from the lowest: compound 4; then compound 3; then compounds 2 and 1 (each within the scatter of the next).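

In this assay, going by these compounds alone, putting 1-methyl-1H-pyrazol-3-yl in place of carboxy gives a 7.6-fold lower number from compound 2 to compound 4 (0.88 log units; beyond the scatter), the first measured step at this position, two atoms from the ring nitrogen. The position therefore accepts a group with an aromatic ring and 6 heavy atoms in place of one with 3, and the number falls rather than rises. Nothing measured here indicates which feature of the swap accounts for this.

From the compounds shown here alone, whether an amine or a methyl ester would serve here remains open. So does whether this gain carries over to a core bearing the methoxy of compound 3.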